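Swapping the Pyrazole Link on a Long Chain

The source may hold more compounds than are shown below. What is called first, only, known or untested is meant among the compounds shown, and "the series" means these compounds.

Measured in a functional assay on SNB-78 cells (Homo sapiens) for inhibition, read by sulforhodamine B assay, with a stated time of 48 h; a higher number here means a weaker inhibitor of growth, a lower number a stronger inhibitor of growth:
- Compound 1 `CCCCCCCCCCCC[C@@H](O)[C@H]1CC[C@H]([C@H](O)CCCCCCCCCCNC(=O)c2ccnn2C)O1`: 100000 nM
- Compound 2 `CCCCCCCCCCCC[C@@H](O)[C@H]1CC[C@H]([C@H](O)CCCCCCCCCCC(=O)Nc2ccnn2C)O1`: 100000 nM

Going by the values given here, compound 2 gives 100000 nM in this assay and stands level with compound 1, its nearest comparison and the only other measured compound. The next compound to be tested is compound 3 `CCCCCCCCCCCC[C@@H](O)[C@H]1CC[C@H]([C@H](O)CCCCCCCCCCOC(=O)c2ccnn2C)O1`. It keeps the shared core and changes one group: ((1-methyl-1H-pyrazol-5-yl)carbonyl)oxy takes the place of (1-methyl-1H-pyrazol-5-yl)carbamoyl on a saturated chain carbon (((1-methyl-1H-pyrazol-5-yl)carbonyl)oxy in place of (1-methyl-1H-pyrazol-5-yl)carbamoyl on a saturated chain carbon, ten or more bonds along the chain from an oxygen on a saturated carbon and a saturated ring carbon).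

Among the compounds with values here, only one measured step bears on this change. Replacing ((1-methyl-1H-pyrazol-5-yl)carbonyl)amino with (1-methyl-1H-pyrazol-5-yl)carbamoyl at the same place gave no change at the digits printed from compound 1 to compound 2 (within the scatter). Within the data shown here, no compound carrying the new group has been measured, so this single step is indirect evidence. Since that step left the value unchanged, no shift beyond the scatter is expected in this assay, although the range is left wide toward stronger inhibition. The expected result is a 1.4-fold lower number from compound 2 to compound 3 (0.15 log units; within the scatter). For compound 3 the estimated value is 70000 nM, with an expected range of 5000 nM to 120000 nM.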

Compound 3, concentration for 50% growth inhibition: 44700 nM
The estimate for compound 3 lay 1.6-fold (0.19 log units) above the measured number, within the range that was stated.
By their numbers in this assay, from the lowest: compound 3; then compounds 1 and 2 (each within the scatter of the next).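

In this assay, going by these compounds alone, the ((1-methyl-1H-pyrazol-5-yl)carbonyl)oxy link gives the first step beyond the scatter at this place on the chain: a 2.2-fold lower number from compound 2 to compound 3 (0.35 log units; beyond the scatter), and likewise a 2.2-fold lower number from compound 1 to compound 3 (0.35 log units; beyond the scatter). Both steps are modest, but they show that the number at this position can respond to the atoms linking the chain to the pyrazole, which the unchanged pair of compound 1 and compound 2 had not shown, and the change from compound 2 brings 0 hydrogen-bond donors and 4 hydrogen-bond acceptors in place of 1 and 3. Nothing measured here accounts for the shift, so those counts describe the change and do not explain it.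

The three compounds leave open whether the lower number belongs to the carbonyloxy link as such, or whether an ether, a carbamate or a sulfonamide at the same place would match it. They also leave open how far the result depends on the 1-methyl-1H-pyrazol-5-yl group or on the chain length, since a phenyl ring or a longer chain could give a different number from the 44700 nM of compound 3.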